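Compound 4: a Further Methoxy on the Carbonyl Aryl Group

The source may hold more compounds than are shown below. What is called first, only, known or untested is meant among the compounds shown, and "the series" means these compounds.

Going by the values given here, compound 1 `COc1ccc(C(=O)/C=C/c2cc(-c3cc(OC)c(OC)c(OC)c3)n[nH]2)cc1OC` stands at the low end of the three numbers so far: in a functional assay on MDA-MB-468 cells (Homo sapiens) for cytotoxicity, read by sulforhodamine B assay, with a stated time of 48 h, tested at 100 uM (a lower number here means a stronger effect, a higher number a weaker effect of the compound at the concentration tested), compound 1 gives -87%. Compound 2 `COc1ccc(C(=O)/C=C/c2cc(-c3cc(OC)c(OC)c(OC)c3)n[nH]2)cc1` gives -78% in this assay, and the step of a number 9 percentage points higher from compound 1 to compound 2 (within the scatter) sits within the scatter, so no order between compound 1 and compound 2 is claimed. Compound 3 `COc1cc(-c2cc(/C=C/C(=O)c3ccc(F)c(F)c3)[nH]n2)cc(OC)c1OC` gives -26%; the steps of a number 61 percentage points higher from compound 1 to compound 3 (beyond the scatter) and a number 52 percentage points higher from compound 2 to compound 3 (beyond the scatter) are both large.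

Compound 4 `COc1cc(C(=O)/C=C/c2cc(-c3cc(OC)c(OC)c(OC)c3)n[nH]2)cc(OC)c1OC` differs from compound 1 in one place: methoxy in place of hydrogen on an aromatic carbon. Among the compounds with values here, the step that bears most directly on this is the one from compound 1 to compound 2, where a methoxy on an aromatic carbon is removed rather than added, and that step is within the scatter. The large steps to compound 3 concern exchange of the whole aryl group on the carbonyl carbon for 3,4-difluorophenyl and say nothing about one more methoxy. No step beyond the scatter is therefore expected in this assay. Compound 4 is estimated at -85%, with a range from -100% to -65%. The step this estimate means, a number 2 percentage points higher from compound 1 to compound 4 (within the scatter), is expected to remain within the scatter.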

Compound 4, a percentage reported as activity, at one concentration (the size of the read-out at that concentration, not a potency): -91%
Compound 4: the middle estimate sits 6 percentage points above what was measured, and the stated range covers the measured number.
By their numbers in this assay, from the lowest: compounds 4, 1 and 2 (each within the scatter of the next, the first and the last beyond it); then compound 3.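

The further methoxy, on an aromatic carbon ortho to a methoxy group and meta to a large group, gives a number 4 percentage points lower from compound 1 to compound 4 (within the scatter) in this assay, so this position accepts the added group without a step that can be read as a gain or a loss. Together with the step of a number 9 percentage points higher from compound 1 to compound 2 (within the scatter), which concerns a methoxy on the same aryl group, this gives two single-place changes in the number of methoxy groups on the carbonyl aryl group, with neither step beyond the scatter; the read-out comes from one concentration and gives no potency, so any difference between these compounds at lower concentrations remains unseen. Nothing on hand explains why the added methoxy leaves the number within the scatter.

Open at this position is whether only a methoxy fits there, or whether a hydroxyl, an amine, a carboxylic acid or a longer chain such as ethoxy would stay within the scatter as well. Also open, on these data alone, is which part of the exchange in compound 3 carries its large step, which a single fluorine or chlorine on an otherwise methoxy-bearing aryl group would help to separate.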